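This account rests on a few compounds, and the source may have more. Where it says the series, first, only, none or still open, it means among the compounds named here.

In a functional assay on THP-1 cells (Homo sapiens) for inhibition, read by ELISA, with stated times of 2 h and 48 h (a lower number here means a stronger inhibitor, a higher number a weaker inhibitor), compound 1 (`[O-]/[N+](=C\c1cn(-c2ccc(F)cc2)nn1)Cc1ccccc1`) gives 9700 nM and compound 2 (`COc1ccc(-n2cc(/C=[N+](\[O-])Cc3ccccc3)nn2)cc1`) gives 17300 nM. Among the measured compounds shown here, these are the only two numbers, and they lie within the scatter of each other: a 1.8-fold higher number from compound 1 to compound 2 (0.25 log units; within the scatter). Compound 3 (`CC(C)(C)/[N+]([O-])=C/c1cn(-c2ccc(F)cc2)nn1`) departs from compound 1 at a different place, with tert-butyl in place of benzyl on a double-bonded nitrogen. For the measured compounds named here, no measured step covers this exchange. The only one available, a 1.8-fold higher number from compound 1 to compound 2 (0.25 log units; within the scatter), is methoxy in place of fluoro on an aromatic carbon, so it bears only indirectly, as a sign that one change elsewhere on the core stayed within the scatter. The data give no direction, and no shift beyond the scatter is expected in this assay, though with low confidence. The estimate amounts to an expected 1.2-fold higher number from compound 1 to compound 3 (0.09 log units; within the scatter). For compound 3 the expected value is 12000 nM, with an estimated range of 4000 nM to 36000 nM.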

Compound 3, half-maximal inhibitory concentration: 14000 nM
For compound 3 the middle estimate is 1.2-fold (0.07 log units) below the measured one; measured number inside the range.
By their numbers in this assay, from the lowest: compounds 1, 3 and 2 (each within the scatter of the next).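

In this assay, among the compounds shown here, this is the first reading at the double-bonded nitrogen, where the earlier pair changed only an aromatic carbon: a 1.4-fold higher number from compound 1 to compound 3 (0.16 log units; within the scatter). Benzyl, with 7 heavy atoms and a six-membered aromatic ring, can therefore give way to tert-butyl, with 4 heavy atoms and no ring, without a shift beyond the scatter, so that ring is not needed at this position for a reading of this size in this assay. No measurement on hand explains why the exchange stays within the scatter.

Still open, going by these compounds, is whether a longer chain, an amine or a carboxylic acid on this nitrogen would move the number beyond the scatter in either direction. On these data alone, the outcome of pairing tert-butyl on this nitrogen with methoxy in place of fluoro on the shared core is also open.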